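The source may report more compounds than this note shows. Statements on the series, on what has been measured and on what is new or still open speak of the compounds shown alone.

Measured so far in a physicochemical assay for lipophilicity, using the shake flask method, in phosphate buffer, measured as octanol-water partition, at pH 7.4 (a higher number here means a more lipophilic compound, a lower number a more polar compound), for two compounds:
- compound 1 `CC[C@H](c1ccc(C(=O)O)c(Oc2cccc(Cl)c2)c1OC)N1CCC[C@H](n2cc(C)c(=O)[nH]c2=O)C1` gives -0.13
- compound 2 `CCC[C@@H](c1ccc(C(=O)O)c(Oc2cccc(Cl)c2)c1OC)N1CCC[C@H](n2cc(C)c(=O)[nH]c2=O)C1` gives 0.13

Compound 2 (0.13) stands within the usual scatter of compound 1 (-0.13), so the two cannot be told apart. Compound 3 `CCC[C@H](c1ccc(C(=O)O)c(Oc2cccc(Cl)c2)c1OC)N1CCC[C@H](n2cc(C)c(=O)[nH]c2=O)C1` has the same atoms and bonds as compound 2 (the two compounds have the same atoms and bonds and differ only in configuration as drawn: 1 of 2 stereo elements differ; a stereocentre at a saturated chain carbon is drawn S in compound 2 and R in compound 3): a stereocentre at a saturated chain carbon is drawn S in compound 2 and R in compound 3. Among the measured compounds shown here, no measured pair shows what such a swap does, so no step beyond the scatter is expected in this assay and no direction can be argued. The step of a number 0.03 log units lower from compound 2 to compound 3 (within the scatter) is an estimate and is expected to stay within the scatter. Compound 3 is expected at 0.1 with an estimated range from -0.3 to 0.5 in this measurement.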

Compound 3, distribution coefficient: 0.08
Estimate against measurement, compound 3: 0.02 log units above, and the stated range covers the measured number.
By their numbers in this assay, from the lowest: compounds 1, 3 and 2 (each within the scatter of the next).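

In this assay, among the compounds shown here, swapping the stereocentre at this saturated chain carbon gives a number 0.05 log units lower from compound 2 to compound 3 (within the scatter) and so offers the first direct reading of such a swap, one that cannot be told apart from repeat measurements: the fact that compounds 2 and 3 differ only in the configuration as drawn. Methyl in place of hydrogen on the same chain gives a number 0.21 log units higher from compound 1 to compound 3 (within the scatter) and also cannot be told apart from repeat measurements. Neither change at this position has yet shifted the number beyond the scatter. On these data alone, whether a butyl chain or a hydroxyl group at this position would do so stays open.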